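The compounds below may be only part of what the source reports. "The series", "measured", "known", "first", "only" and "open" are said of these compounds alone.

Within the data shown here, compound 1 `C=CCCCSC[C@H](NC(=O)c1cc(O)c(O)c(O)c1)C(=O)OC` is the first of three close analogues built on a shared core. In an assay on RAW264.7 cells for antagonist activity at Toll-like receptor 2 (Mus musculus), read by Griess assay, with a stated time of 24 h (on this read-out lower numbers stand for stronger inhibition and higher numbers for weaker inhibition), compound 1 gives 39200 nM, the lowest of the three numbers, though its neighbours sit within the scatter: compound 2 `C#CCSC[C@H](NC(=O)c1cc(O)c(O)c(O)c1)C(=O)OC` gives 71500 nM and compound 3 `COC(=O)[C@H](CSCc1ccccc1)NC(=O)c1cc(O)c(O)c(O)c1` gives 60700 nM. The steps of a 1.8-fold higher number from compound 1 to compound 2 (0.26 log units; within the scatter) and a 1.5-fold higher number from compound 1 to compound 3 (0.19 log units; within the scatter) both change only the group on the saturated chain carbon bound to the sulfur. Compound 4 `C=CCCCSC[C@H](NC(=O)c1cc(O)cc(O)c1)C(=O)OC` instead differs from compound 1 by hydrogen in place of hydroxy on an aromatic carbon. Among the measured compounds shown here, no measured step touches the ring hydroxy groups, so none bears directly on this change. Compound 4 is therefore expected to stay near compound 1, with a step of a 1.5-fold higher number from compound 1 to compound 4 (0.18 log units; within the scatter) in this assay, giving an estimated 60000 nM within 25000 nM to 150000 nM.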

Compound 4, half-maximal inhibitory concentration: 57800 nM
Beside the measured number, compound 4's estimate is 1.0-fold (0.02 log units) above it; low and high end bracket the measured number.
By their numbers in this assay, from the lowest: compounds 1, 4, 3 and 2 (each within the scatter of the next).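

Among these compounds, the result gives the first reading on the ring of the shared core. In this assay, hydrogen in place of hydroxy, on the aromatic carbon ortho to two hydroxy groups and para to a large group, gives a 1.5-fold higher number from compound 1 to compound 4 (0.17 log units; within the scatter) for this step. This hydroxy group can thus be lost without a change that stands clear of the scatter, and no evidence on the cause is available.

From the compounds shown here alone, it remains open whether a methoxy group or an amine on this carbon would behave the same way. Going by these compounds, the effect of removing the two remaining hydroxy groups also remains open.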